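Isopropyl to cyclohexyl on the amide carbonyl

A few compounds are considered here, and "the series" means these few. Any claim that something is new, unique, unknown or untested is made for them only; others in the source may bear on it.

Measured so far in an assay on isolated protein with Bile acid receptor (Homo sapiens) as the target; a lower number here means that less compound is needed, a higher number that more compound is needed for the effect:
compound 1 `CCOc1cccc(-c2ccc(CN(C(=O)C(C)C)c3cccc(/C=C/C(=O)OC)c3)cc2)c1` gives 173 nM;
compound 2 `COC(=O)/C=C/c1cccc(N(Cc2ccc(-c3cccc(Cl)c3)cc2)C(=O)C(C)C)c1` gives 77 nM;
compound 3 `COC(=O)/C=C/c1cccc(N(Cc2ccc(-c3cccc(OC(F)(F)F)c3)cc2)C(=O)C(C)C)c1` gives 247 nM.

Compound 3 has the highest number of the three in this assay. Its gap to compound 1 is within the scatter, while its gap to compound 2 is beyond it: a 3.2-fold higher number from compound 2 to compound 3 (0.51 log units; beyond the scatter). Compound 4 `COC(=O)/C=C/c1cccc(N(Cc2ccc(-c3cccc(OC(F)(F)F)c3)cc2)C(=O)C2CCCCC2)c1` differs from compound 3 by cyclohexyl in place of isopropyl on a carbonyl carbon. Among the compounds with values here, no measured step touches this carbonyl substituent: the two steps beyond the scatter, a 2.2-fold lower number from compound 1 to compound 2 (0.35 log units; beyond the scatter) and a 3.2-fold higher number from compound 2 to compound 3 (0.51 log units; beyond the scatter), both concern the substituent on the aromatic ring, and a 1.4-fold higher number from compound 1 to compound 3 (0.15 log units; within the scatter) is within the scatter. Nothing in the series points in either direction, so the expected step of a 1.0-fold higher number from compound 3 to compound 4 (0.01 log units; within the scatter) is none beyond the scatter. Compound 4 is estimated at 250 nM, between 80 nM and 800 nM, with a wide range reflecting the lack of any bearing step.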

Compound 4, half-maximal effective concentration: 420 nM
Compound 4: middle estimate off by 1.7-fold (0.23 log units), on the low side; measured number inside the range.
By their numbers in this assay, from the lowest: compound 2; then compounds 1, 3 and 4 (each within the scatter of the next, the first and the last beyond it).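

Within the data shown here, the carbonyl substituent changes here for the first time. In this assay, cyclohexyl in place of isopropyl on a carbonyl carbon gives a 1.7-fold higher number from compound 3 to compound 4 (0.23 log units; within the scatter), so raising the heavy atoms of this substituent from 3 to 6 and adding a ring leaves the number within the scatter. Nothing available bears on the reason for this result.

Open, as far as these compounds go, is whether the same holds with the chloro substituent of compound 2 on the aromatic ring. Also open, from the compounds shown here alone, is how a phenyl or a tert-butyl on this carbonyl carbon, or a carboxylic acid in place of the methyl ester, would read.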